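The source may hold more compounds than are shown below. What is called first, only, known or untested is meant among the compounds shown, and "the series" means these compounds.

Compound 1 `COc1ccc(C(=O)N2CCN(Cc3nc4ccccc4n3Cc3cccc(C)c3)CC2)cc1` gives 55.5% in an assay on isolated protein for inhibition of aldehyde dehydrogenase 1A1 (Homo sapiens), read by spectrophotometry, tested at 10 uM; on this read-out higher numbers stand for more inhibition at the one concentration tested (going by the name of the read-out) and lower numbers for less inhibition. Compound 2 `Cc1cccc(Cn2c(CN3CCN(C(=O)C4CCCCC4)CC3)nc3ccccc32)c1` gives 31.9%. Compound 3 `CC(C)=CCn1c(CN2CCN(C(=O)C3CC3)CC2)nc2ccccc21` gives 74.3%.

Compound 3 stands highest of the three numbers; compound 1 lies nearest below it, compound 2 furthest. Compound 4 `O=C(C1CC1)N1CCN(Cc2nc3ccccc3n2Cc2ccccc2F)CC1` differs from compound 3 in one place: 2-fluorophenyl in place of 2-methylprop-1-en-1-yl on a saturated chain carbon bound to an aromatic nitrogen. Among the compounds with values here, the single measured step, a number 23.6 percentage points lower from compound 1 to compound 2 (beyond the scatter), concerns the carbonyl carbon, not the carbon bound to the aromatic nitrogen, so no measured step bears directly on this change. Compounds 1 and 2, which carry a ring on that carbon, both lie below compound 3, but they differ from it at the carbonyl as well. A downward step a number 19.3 percentage points lower from compound 3 to compound 4 (beyond the scatter) is therefore expected, with wide uncertainty, and compound 4 is estimated at 55%, between 30% and 80%.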

Compound 4, a percentage reported as inhibition, at one concentration (the size of the read-out at that concentration, not a potency): 40.7%
For compound 4 the middle estimate is 14.3 percentage points above the measured one; measured number inside the range.
By their numbers in this assay, from the lowest: compounds 2 and 4 (each within the scatter of the next); then compound 1; then compound 3.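

With the carbonyl side held constant, 2-fluorophenyl in place of 2-methylprop-1-en-1-yl on a saturated chain carbon bound to an aromatic nitrogen gives a number 33.6 percentage points lower from compound 3 to compound 4 (beyond the scatter) in this assay. This position, like the carbonyl carbon, therefore moves the read-out beyond the scatter. Nothing shown here explains the size of this step. On these data alone, whether the fall goes with the aromatic ring or with its fluorine stays open, as this position rests on a single pair. A plain benzyl or a saturated chain such as 3-methylbutyl would bear on that.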